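The source may hold more compounds than are shown below. What is called first, only, known or untested is meant among the compounds shown, and "the series" means these compounds.

Working notes on the series. In a physicochemical assay for solubility, read by HPLC (a lower number here means a less soluble compound, a higher number a more soluble compound), compound 1 (`CC(=O)NC[C@H]1CN(c2ccc(OC[C@@H](O)CNc3ccc(C#N)cc3)c(F)c2)C(=O)O1`) gives 47000 nM and compound 2 (`CC(=O)NC[C@H]1CN(c2ccc(OC[C@H](O)CNc3cc(C(F)(F)F)cc(C(F)(F)F)c3)c(F)c2)C(=O)O1`) gives 22000 nM. Compound 3 (`CC(=O)NC[C@H]1CN(c2ccc(OC[C@H](O)CNc3ccccn3)c(F)c2)C(=O)O1`) gives 35100000 nM, the highest of the three numbers, and the other two lie beyond the scatter below it.

The next compound is compound 4 (`CC(=O)NC[C@H]1CN(c2ccc(OC[C@H](O)CNCCC(C)C)c(F)c2)C(=O)O1`). Its difference from compound 3 is isopentyl in place of pyridin-2-yl on an amine nitrogen. For the measured compounds named here, no measured pair isolates a single change, so the size of this step has no direct precedent.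

Compound 3 at 35100000 nM is the top of the range seen so far, so a fall towards the other two is the likelier direction. A drop beyond the scatter in this assay is expected, though smaller than the gaps from compound 3 to the other two compounds. The estimated change is a 12-fold lower number from compound 3 to compound 4 (1.07 log units; beyond the scatter). For compound 4 the expected value is 3000000 nM, with an estimated range of 200000 nM to 30000000 nM.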

Compound 4, solubility: 7280000 nM
The estimate for compound 4 lay 2.4-fold (0.39 log units) below the measured number; the range from low to high includes it.
By their numbers in this assay, from the lowest: compound 2; then compound 1; then compound 4; then compound 3.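

In this assay, the series now has its first change in a single place: isopentyl in place of pyridin-2-yl on an amine nitrogen gives a 4.8-fold lower number from compound 3 to compound 4 (0.68 log units; beyond the scatter). The step is modest but beyond the scatter, and it shows that this nitrogen can carry an open chain with no ring and no hydrogen-bond acceptor while compound 4 still reads 7280000 nM. No measurement shown here accounts for the size of the step.

From the compounds shown here alone, the step replaces the ring and its nitrogen together, so their separate contributions remain open; a phenyl group on the same amine nitrogen would separate them. Going by these compounds, whether the number follows chain length or a chain's end group also remains open, and a longer chain or a chain ending in a carboxylic acid would test this.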